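Hydroxyphenyl in place of methoxypyridinyl on a shared core

The source may hold more compounds than are shown below. What is called first, only, known or untested is meant among the compounds shown, and "the series" means these compounds.

Compound 1 `COc1ccc(C(=O)/C=C/c2ccc(F)cc2)c2c1C=CC(C)(C)O2`: in a functional assay on HCT-116 cells (Homo sapiens) for antiproliferative activity, read by MTT assay, with a stated time of 24 h (on this read-out higher numbers stand for weaker inhibition and lower numbers for stronger inhibition), compound 1 gives > 10000 nM, a limit of the assay.
Compound 2 `COc1ccc(C(=O)/C=C/c2ccc(-c3ccccc3)cc2)c2c1C=CC(C)(C)O2`: compound 2 gives > 10000 nM, a limit of the assay.
Compound 3 `COc1ccc(/C=C/C(=O)c2ccc(OC)c3c2OC(C)(C)C=C3)cn1`: compound 3 gives > 10000 nM, a limit of the assay.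

Compound 3 therefore stands at the edge of what this assay can report, and so does every other measured compound, because of the limit of > 10000 nM in this assay, at which 3 of the 3 values shown sit. Among the compounds with values here, the two measured steps, a step that the two limits leave unreadable from compound 1 to compound 2 and a step that the two limits leave unreadable from compound 1 to compound 3, are both unreadable, so no measured step gives a size for the change to compound 4 `COc1ccc(C(=O)/C=C/c2ccc(O)cc2)c2c1C=CC(C)(C)O2`. The change itself is 4-hydroxyphenyl in place of 6-methoxypyridin-3-yl on a double-bonded chain carbon bound to a double-bonded chain carbon. With no readable step to lean on, compound 4 is expected to sit near the same limit, with an estimated value of 10000 nM, ranging from 2000 nM to 30000 nM. The expected step is a number no higher from compound 3 to compound 4 (the limit leaves the size open).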

Compound 4, half-maximal inhibitory concentration: > 10000 nM
Compound 4: a limit, no number; the forecaster's own chance of this, stated with the estimate: 70%; the middle value lies on the limit itself.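

No step from compound 1, compound 2 or compound 3 to compound 4 can be read, because every value is a limit and not a number: the limit of > 10000 nM in this assay, at which 4 of the 4 values shown sit.

As far as these compounds go, how strongly any of these four compounds inhibits the cells, and whether the changed groups make any difference, remains open.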